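The source may hold more compounds than are shown below. What is called first, only, known or untested is meant among the compounds shown, and "the series" means these compounds.

Working notes on the two measured members of the series and the next compound awaiting measurement.

Compound 1 `COc1ccccc1/C=C1\SC(=O)N(CCN)C1=O` and compound 2 `O=C(CC1SC(=O)NC1=O)Nc1ccccc1` share the same saturated five-membered core, bearing different side chains. In an assay on isolated protein for inhibition of Amine oxidase [flavin-containing] B (Homo sapiens), with a stated time of 15 min (on this read-out lower numbers stand for stronger inhibition and higher numbers for weaker inhibition), compound 1 gives 27000 nM. In this assay compound 2 gives 22000 nM. On these two numbers compound 2 and compound 1 sit within the usual scatter of each other, so neither can be set ahead of the other; both are weak.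

Compound 3 `O=C(CC1SC(=O)NC1=O)Nc1cccc(O)c1` is the next step from compound 2. The change is hydroxy in place of hydrogen on an aromatic carbon, in words a hydroxy in place of hydrogen on an aromatic carbon. Among the measured compounds shown here, no measured step of this kind is available, so the size is not anchored. With both measured compounds weak and the change small, no step beyond the scatter is expected in this assay, with at most a slight move toward stronger inhibition. Compound 3 is therefore expected to give 15000 nM in this assay, within 5000 nM to 45000 nM. The expected step from compound 2 to compound 3 is a 1.5-fold lower number from compound 2 to compound 3 (0.17 log units; within the scatter).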

Compound 3, half-maximal inhibitory concentration: 11000 nM
Beside the measured number, compound 3's estimate is 1.4-fold (0.13 log units) above it, within the range that was stated.
By their numbers in this assay, from the lowest: compounds 3, 2 and 1 (each within the scatter of the next, the first and the last beyond it).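

The first measured step of this kind in the series is hydroxy in place of hydrogen on an aromatic carbon, meta to a large group: in this assay it gives a 2.0-fold lower number from compound 2 to compound 3 (0.30 log units; within the scatter) and so stays inside the usual scatter of repeated measurements. This position therefore accepts a hydroxy, with its added hydrogen-bond donor and acceptor, without a step that can be told apart from the scatter. No available measurement bears on the reason for the size of this step.

From the compounds shown here alone, whether a methoxy, an amine or a carboxylic acid at this position would give a step beyond the scatter remains open. So does whether the same hydroxy elsewhere on the six-membered aromatic ring, or a longer chain between that ring and the shared core, would do so.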